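From 4-fluorophenyl to 2-fluorophenyl: compound 1 and compound 4

This account rests on a few compounds, and the source may have more. Where it says the series, first, only, none or still open, it means among the compounds named here.

In a toxicity assay on cells (Macrophage, Mus musculus, strain BALB/c) for cytotoxicity, read by MTT assay (a higher number here means a weaker inhibitor, a lower number a stronger inhibitor), compound 1 `C=CCOc1cc(OC)c(C(=O)/C=C/c2ccc(F)cc2)c(OCC=C)c1` gives 13800 nM and compound 2 `COc1cc(O)cc(O)c1C(=O)/C=C/c1ccc(Cl)cc1` gives 19000 nM so that the two numbers sit within the usual scatter of each other, and no order can be drawn between them. Compound 3 `COCc1cc(COC)c(C(=O)/C=C/c2ccc(OC)cc2)c(OC)c1` yields no number, only a limit of the assay at > 250000 nM as its reading. Compound 1 therefore stands level with compound 2, its nearest neighbour among the measured values.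

Compound 4 `C=CCOc1cc(OC)c(C(=O)/C=C/c2ccccc2F)c(OCC=C)c1` has not yet been measured. It has the same atoms as compound 1, joined differently: 2-fluorophenyl in place of 4-fluorophenyl on a double-bonded chain carbon bound to a double-bonded chain carbon is the whole change, with 2-fluorophenyl in place of 4-fluorophenyl on a double-bonded chain carbon bound to a double-bonded chain carbon. Among the measured compounds shown here, no measured pair in this small set isolates such a change, so the data give no direct guide to its size. The expectation starts instead from compound 1 at 13800 nM and assumes no shift beyond the scatter in this assay in either direction. The expected step of a 1.1-fold higher number from compound 1 to compound 4 (0.04 log units; within the scatter) is estimated to be small. The estimate for compound 4 is 15000 nM with an expected range from 6500 nM to 35000 nM in this measurement.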

Compound 4, half-maximal inhibitory concentration: 13300 nM
Compound 4: middle estimate off by 1.1-fold (0.05 log units), on the high side; the measured number falls inside the stated range.
By their numbers in this assay, from the lowest: compounds 4, 1 and 2 (each within the scatter of the next). At a limit, above all of these: compound 3.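

In this assay, among the compounds shown here, 2-fluorophenyl in place of 4-fluorophenyl on a double-bonded chain carbon bound to a double-bonded chain carbon gives a 1.0-fold lower number from compound 1 to compound 4 (0.02 log units; within the scatter) and so provides the first pair in this set that differs in one place. With the same atoms joined differently, the two compounds stand level, and this assay does not tell the two fluorophenyl groups apart at this position, something compound 2 and compound 3 could not show because neither differs from compound 1 in one place alone. No measurement shown here bears on a cause for this level reading.

Whether the fluorine itself counts for anything at this position remains open, as the compounds shown include no plain phenyl group in this series and none with an amine or a carboxylic acid on the ring in its place. As far as these compounds go, it is also open whether the two fluorophenyl groups would still read level if the two allyl ether groups on the shared core gave way to a longer chain.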